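Swapping a Ring Hydroxy for Fluoro in a Phenol Series

The source may hold more compounds than are shown below. What is called first, only, known or untested is meant among the compounds shown, and "the series" means these compounds.

Compound 1, `C[C@@H]1CC[C@@H]2[C@@H](C1)O[C@@H](c1ccccc1)CC2(C)O`: 580000 nM
Compound 2, `C[C@@H]1CC[C@@H]2[C@@H](C1)O[C@@H](c1ccccc1O)CC2(C)O`: > 1080000 nM
Compound 3, `COc1ccc(OC)c([C@H]2CC(C)(F)[C@@H]3CC[C@@H](C)C[C@H]3O2)c1`: 37000 nM

Of the compounds shown here, three have been measured in an ADME assay on MDCK cells (Canis lupus familiaris) for cytotoxicity, read by MTT assay, with a stated time of 48 h; a lower number here means that less compound is tolerated, a higher number that more compound is tolerated. Compound 1 gives 580000 nM. For compound 2 only a limit of the assay is known, > 1080000 nM, so compound 2 stands at the limit of > 1080000 nM in this assay, at which 1 of the 3 values shown sits. Going by the values given here, the single measured step is an at least 1.8-fold higher number from compound 1 to compound 2 (0.26 log units; that floor lies within the scatter), which concerns hydroxy entering on an aromatic carbon. Among the compounds with values here, compound 3 gives 37000 nM; it carries fluoro on the saturated ring carbon, but it also carries two methoxy groups on the aromatic ring, so no single step links compound 3 to compound 2.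

Compound 4, `C[C@@H]1CC[C@@H]2[C@@H](C1)O[C@@H](c1ccccc1O)CC2(C)F`, is to be measured in this assay. It differs from compound 2 by fluoro in place of hydroxy on a saturated ring carbon. Within the data shown here, no measured step isolates this change: the step from compound 1 to compound 2 touches a different position and a different group, and compound 3 differs from compound 2 in two places at once. The expectation therefore rests mainly on compound 3 with its 37000 nM, which suggests that fluoro at this position goes with a lower number, but with wide uncertainty. Compound 4 is estimated at 250000 nM, within 50000 nM to 1080000 nM, an expected step of an at least 4.3-fold lower number from compound 2 to compound 4 (0.63 log units; beyond the scatter).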

Compound 4, half-maximal cytotoxic concentration: 44000 nM
Compound 4: middle estimate off by 5.7-fold (0.75 log units), on the high side; measured number outside the range, below it.
By their numbers in this assay, from the lowest: compounds 3 and 4 (each within the scatter of the next); then compound 1. At a limit, above all of these: compound 2.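

In this assay, the exchange of hydroxy for fluoro on the saturated ring carbon now stands alone, with the rest of compound 2 unchanged, and it gives an at least 24-fold lower number from compound 2 to compound 4 (1.38 log units; beyond the scatter). Going by these compounds alone, this is the first single-place reading at this position, and it shows that this one change is enough to produce a large step beyond the scatter; the only earlier step, an at least 1.8-fold higher number from compound 1 to compound 2 (0.26 log units; that floor lies within the scatter), concerned an aromatic carbon and so said nothing about this site. The size of the new step is a floor and not a fixed figure, because compound 2 is known only as a limit of the assay: the limit of > 1080000 nM in this assay, at which 1 of the 4 values shown sits.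

On these data alone, it remains open whether fluoro on this carbon lowers the number to the same degree on the core of compound 1, with no hydroxy on the aromatic ring. The compounds shown also give no reading for another group on this carbon, such as an amine or a chloro, so they cannot tell whether the step follows the loss of hydroxy or the arrival of fluoro.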